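A few compounds are considered here, and "the series" means these few. Any claim that something is new, unique, unknown or untested is made for them only; others in the source may bear on it.

Measured compounds:
compound 1 `CCCC(=O)N1N=C(c2cc(Cl)ccc2N)SC1(C)C` — 66.2%
compound 2 `CC1(C)SC(c2cc(Cl)ccc2N)=NN1C(=O)C1CC1` — 23.2%
compound 3 `CC1(C)SC(c2cc(Cl)ccc2N)=NN1C(=O)C1CCC1` — -4.65%

All three share one core and differ only in the group on the carbonyl carbon. In an assay on isolated protein for inhibition of Nitric oxide synthase, inducible (Homo sapiens), read by scintillation counting, with a stated time of 30 min, tested at 50 uM (a lower number here means less inhibition, a higher number more inhibition at the concentration tested (going by the name of the read-out)), compound 1 gives 66.2%, the highest of the three numbers. The nearest is compound 2 with 23.2%, the step being a number 43 percentage points lower from compound 1 to compound 2 (beyond the scatter); the furthest is compound 3 with -4.65%, the step being a number 70.9 percentage points lower from compound 1 to compound 3 (beyond the scatter). Between the two ring-bearing compounds the step is a number 27.9 percentage points lower from compound 2 to compound 3 (beyond the scatter).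

Compound 4 `CCCC(=O)N1N=C(c2ccccc2N)SC1(C)C` has not been measured in this assay. It differs from compound 1 only on the aromatic ring: hydrogen in place of chloro on an aromatic carbon. Within the data shown here, none of the measured steps touches that place; all three alter the group on the carbonyl carbon, so they give no direct guide to the size or direction of the change from compound 1 to compound 4. Without any measured change at the aromatic carbon, the expectation rests on compound 1 alone, and a step of modest size downward, not far beyond the scatter, is expected, with a wide range: a number 16.2 percentage points lower from compound 1 to compound 4 (beyond the scatter) is the expected step. For compound 4 the estimate is 50%, with a range from 20% to 75%.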

Compound 4, a percentage reported as inhibition, at one concentration (the size of the read-out at that concentration, not a potency): 35.2%
Compound 4: the middle estimate sits 14.8 percentage points above what was measured, and the stated range covers the measured number.
By their numbers in this assay, from the lowest: compound 3; then compound 2; then compound 4; then compound 1.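

Among these compounds, the aromatic carbon para to an amino group is the first place outside the carbonyl substituent to be probed, and it responds: hydrogen in place of chloro gives a number 31 percentage points lower from compound 1 to compound 4 (beyond the scatter), a large step of the same printed class as a number 43 percentage points lower from compound 1 to compound 2 (beyond the scatter). The number of compound 1 in this assay therefore depends on the chloro as well as on the propyl group, although compound 4 still gives 35.2% with hydrogen at that carbon, so the chloro is not needed for some inhibition at the concentration tested. Nothing on hand accounts for the size of this step.

Chloro and hydrogen are the only two groups seen at this carbon, so it remains open whether fluoro, bromo, methyl or methoxy would hold or raise the number of compound 1. The step is also read only with propyl on the carbonyl carbon, and whether removing the chloro costs as much with cyclopropyl or cyclobutyl there cannot be told from these compounds.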